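The source may hold more compounds than are shown below. What is called first, only, known or untested is meant among the compounds shown, and "the series" means these compounds.

In a functional assay on HL-60 cells (Homo sapiens) for antiproliferative activity, read by sulforhodamine B assay, with a stated time of 72 h (a lower number here means a stronger inhibitor, a higher number a weaker inhibitor), compound 1 `NC(=S)N/N=C/c1cc2cccnc2s1` gives > 100000 nM, which is a limit of the assay. Going by the values given here, compound 2 `S=C(NCc1ccccc1)N/N=C/c1ccc2ccccc2n1` gives 21900 nM, the only actual number so far. Compound 3 `S=C(N/N=C/c1ccc2ccccc2n1)Nc1ccc(Cl)cc1` has 4-chlorophenyl in place of benzyl on an amide-type nitrogen. Among the compounds with values here, no measured step covers this exchange, so the estimate rests on compound 2 at 21900 nM alone. In this assay a moderate move towards stronger inhibition is expected, a 2.4-fold lower number from compound 2 to compound 3 (0.39 log units; beyond the scatter), with little certainty about its size or direction. Compound 3 is expected at 9000 nM, within an estimated range of 2000 nM to 40000 nM.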

Compound 3, half-maximal inhibitory concentration: > 100000 nM
Compound 3: no number, only a limit (the forecaster's own chance of this, stated with the estimate: 8%); middle value at least 11-fold (1.04 log units) away from the limit.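

On the amide-type nitrogen, 4-chlorophenyl in place of benzyl gives an at least 4.5-fold higher number from compound 2 to compound 3 (0.65 log units; beyond the scatter) in this assay, so the measurable activity of compound 2 depends on the group at this position. The shared core alone does not carry that activity. The step gives only a lower bound on the change because compound 3 stands at a limit, not a number: the limit of > 100000 nM in this assay, at which 2 of the 3 values shown sit.

Going by these compounds, whether phenyl, 4-chlorobenzyl or a longer chain such as phenethyl on this nitrogen keeps the activity of compound 2 stays open. The change therefore cannot be assigned to the chlorine or to the benzyl linker.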